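The compounds below may be only part of what the source reports. "The series", "measured", "known", "first", "only" and "open" are said of these compounds alone.

Compound 2 `COc1ccc(CNC(=N)[C@@H]2CCC(=O)N2Cc2ccccc2[N+](=O)[O-])cc1` gives in a functional assay on SH-SY5Y cells (Homo sapiens) for cytotoxicity, read by MTT assay, with stated times of 8 h, 30 min and 12 h, tested at 0.5 uM (a lower number here means a weaker effect, a higher number a stronger effect of the compound at the concentration tested), 21.1%. For the measured compounds named here, it holds the smaller of the two numbers measured so far, yet this says little, since compound 1 `N=C(NCc1ccc(O)cc1)[C@@H]1CCC(=O)N1Cc1ccccc1[N+](=O)[O-]` gives 26.9% and the step of a number 5.8 percentage points lower from compound 1 to compound 2 (within the scatter) falls within the scatter, so no order between the two can be read. Compound 3 `COc1ccc(CNC(=N)[C@@H]2CCC(=O)N2Cc2ccc(C)cc2)cc1` has not yet been measured; it differs from compound 2 in one place: 4-methylphenyl in place of 2-nitrophenyl on a saturated chain carbon bound to an amide-type nitrogen in a ring. Going by the values given here, the one step measured concerns a methyl in place of hydrogen on an oxygen on an aromatic ring, a part that compound 3 keeps unchanged, so no measured step bears on the exchange of the 2-nitrophenyl for the 4-methylphenyl. With nothing to point either way, compound 3 is expected to stay near compound 2, the step of a number 0.9 percentage points higher from compound 2 to compound 3 (within the scatter) expected to lie within the scatter. Compound 3 is thus estimated at 22%, between 6% and 40%.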

Compound 3, a percentage reported as activity, at one concentration (the size of the read-out at that concentration, not a potency): 21.9%
Beside the measured number, compound 3's estimate is 0.1 percentage points above it; the measured number falls inside the stated range.
By their numbers in this assay, from the lowest: compounds 2, 3 and 1 (each within the scatter of the next).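

Up to here only the oxygen on the aromatic ring had been varied; compound 3 is the first to probe the saturated chain carbon bound to an amide-type nitrogen in a ring. In this assay the exchange gives a number 0.8 percentage points higher from compound 2 to compound 3 (within the scatter) and so no order can be read between the two. In this pair, a number of this size therefore does not depend on the 2-nitrophenyl, as the 4-methylphenyl, with no hydrogen-bond acceptors in place of two, gives a matching result. No measurement offered here explains this outcome. The exchange alters both the group on the aromatic ring and where it sits, and these two changes cannot be separated here. Also open, from the compounds shown here alone, is whether an amine, a carboxylic acid or a longer chain at this place would move the number beyond the scatter.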